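A few compounds are considered here, and "the series" means these few. Any claim that something is new, unique, unknown or untested is made for them only; others in the source may bear on it.

Compound 2, `O=C(/C=C/c1ccc(F)cc1)Nc1ccc(CC2=CC(=O)OC2)cc1`, has the lower of the two measured numbers: in an assay on isolated protein for inhibition of DNA topoisomerase 1 (Homo sapiens), with a stated time of 30 min, tested at 100 uM (a higher number here means more inhibition at the concentration tested (going by the name of the read-out), a lower number less inhibition), compound 2 gives 12.1%. Compound 1, `C=C1OC(=O)C=C1Cc1ccc(NC(=O)/C=C/c2ccccc2)cc1`, gives 48.6% in this assay, and the two values are clearly apart. Compound 3, `C=C1OC(=O)C=C1Cc1ccc(NC(=O)/C=C/c2ccc(F)cc2)cc1`, differs from compound 2 by a group of 7 heavy atoms (5 carbon, 2 oxygen; one five-membered non-aromatic ring with 1 hetero atom) in place of a group of 6 heavy atoms (4 carbon, 2 oxygen; one five-membered non-aromatic ring with 1 hetero atom), on a saturated chain carbon bound to an aromatic carbon, which is the ring that compound 1 carries. Among the measured compounds shown here, with no single-change step between measured compounds, the direction is uncertain, but the value of compound 1 in this assay, 48.6%, suggests an upward step is expected for compound 3, estimated at a number 22.9 percentage points higher from compound 2 to compound 3 (beyond the scatter), giving an expected 35% in the range 10% to 60%.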

Compound 3, a percentage reported as inhibition, at one concentration (the size of the read-out at that concentration, not a potency): 94.1%
For compound 3 the middle estimate is 59.1 percentage points below the measured one; the whole stated range lies below it.
By their numbers in this assay, from the lowest: compound 2; then compound 1; then compound 3.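

At the saturated chain carbon bound to an aromatic carbon, the group of 7 heavy atoms in place of the group of 6 heavy atoms gives a number 82 percentage points higher from compound 2 to compound 3 (beyond the scatter) in this assay, so this ring change matters greatly when fluoro is present. With that ring kept, fluoro in place of hydrogen on an aromatic carbon also counts, giving a number 45.5 percentage points higher from compound 1 to compound 3 (beyond the scatter) in this assay. Nothing measured here explains either step. On these data alone, whether the fluoro step also holds with the ring of compound 2 stays open, as does what a chloro or methoxy group would do in its place.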